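Moving the trifluoromethyl around the ring on the triazole

A few compounds are considered here, and "the series" means these few. Any claim that something is new, unique, unknown or untested is made for them only; others in the source may bear on it.

In a functional assay on HepG2 cells (Homo sapiens) for inhibition, read by MTT assay, with a stated time of 72 h (a lower number here means a stronger inhibitor, a higher number a weaker inhibitor), compound 1 `O=C(Nc1cccc(OCc2cn(-c3ccccc3F)nn2)c1)Nc1ccc(Cl)c(C(F)(F)F)c1` gives 1520 nM and compound 2 `O=C(Nc1cccc(OCc2cn(-c3ccccc3C(F)(F)F)nn2)c1)Nc1ccc(Cl)c(C(F)(F)F)c1` gives 2320 nM; the step of a 1.5-fold higher number from compound 1 to compound 2 (0.18 log units; within the scatter) is small, and compound 2 has the highest of the two numbers, with compound 1 nearest and within the scatter. Compound 3 `O=C(Nc1cccc(OCc2cn(-c3ccc(C(F)(F)F)cc3)nn2)c1)Nc1ccc(Cl)c(C(F)(F)F)c1` keeps the same atoms, joined differently: 4-(trifluoromethyl)phenyl in place of 2-(trifluoromethyl)phenyl on an aromatic nitrogen. Within the data shown here, no measured step moves a group from one place to another, so nothing bears directly on it; the single step seen was within the scatter. Compound 3 is therefore expected to show a 1.2-fold lower number from compound 2 to compound 3 (0.06 log units; within the scatter), no step beyond the scatter, and an estimated 2000 nM, ranging from 800 nM to 5000 nM.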

Compound 3, half-maximal inhibitory concentration: 1800 nM
Compound 3: the middle estimate sits 1.1-fold (0.05 log units) above what was measured, and the stated range covers the measured number.
By their numbers in this assay, from the lowest: compounds 1, 3 and 2 (each within the scatter of the next).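

In this assay the move from 2-(trifluoromethyl)phenyl to 4-(trifluoromethyl)phenyl on the aromatic nitrogen gives a small step (a 1.3-fold lower number from compound 2 to compound 3 (0.11 log units; within the scatter)), so shifting the trifluoromethyl around this ring produces no change beyond the scatter. Exchanging 2-fluorophenyl for 4-(trifluoromethyl)phenyl is equally small (a 1.2-fold higher number from compound 1 to compound 3 (0.07 log units; within the scatter)), leaving all three rings indistinguishable here. Nothing available explains this result. As far as these compounds go, whether an amine or a carboxylic acid on this ring would shift the number beyond the scatter remains open.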